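A fluoro for a methyl: compound 3 to compound 4

The source may hold more compounds than are shown below. What is called first, only, known or untested is meant among the compounds shown, and "the series" means these compounds.

Compound 1 `Cc1ccc(S(=O)(=O)NC(C2=CC(=O)c3c(O)ccc(O)c3C2=O)C(C)C)cc1`: "not determined" (no result reported)
Compound 2 `CC(C)C(NS(=O)(=O)c1ccc(Br)cc1)C1=CC(=O)c2c(O)ccc(O)c2C1=O`: "not determined" (no result reported)
Compound 3 `Cc1ccc(S(=O)(=O)NC(C)C2=CC(=O)c3c(O)ccc(O)c3C2=O)cc1`: 30 nM

In a functional assay on HL-60 cells (Homo sapiens) for cytotoxicity, read by MTT assay (on this read-out higher numbers stand for weaker inhibition and lower numbers for stronger inhibition), only compound 3 gives a number, 30 nM. Compound 1 and compound 2 have no reported result, so compound 3 cannot be ranked against either of them, and its value stands alone.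

Compound 4 `CC(NS(=O)(=O)c1ccc(F)cc1)C1=CC(=O)c2c(O)ccc(O)c2C1=O` has not yet been measured. It departs from compound 3 in a single place: fluoro in place of methyl on an aromatic carbon. This is fluoro in place of methyl on an aromatic carbon, para to a large group, so that 4-methylphenyl becomes 4-fluorophenyl.

No two measured compounds differ in just one place, so the data offer no direct precedent for this exchange and no reason to favour either direction. The expectation therefore rests on compound 3 alone, at 30 nM, and no change beyond the usual scatter of this assay is anticipated. The estimated move is small, a 1.2-fold higher number from compound 3 to compound 4 (0.07 log units; within the scatter). With so little to go on, the range is kept wide. Compound 4 is expected at 35 nM, with an estimated range of 12 nM to 100 nM.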

Compound 4, half-maximal inhibitory concentration: 90 nM
Compound 4: middle estimate off by 2.6-fold (0.41 log units), on the low side; the range from low to high includes it.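

In this assay, among these compounds, replacing methyl with fluoro on an aromatic carbon, para to a large group, gives a 3.0-fold higher number from compound 3 to compound 4 (0.48 log units; beyond the scatter), and this is the only step in the set that can be read. It shows that this position is sensitive to the exchange, since the step lies beyond the scatter even though one heavy atom replaces another and the counts of rings, hydrogen-bond donors, hydrogen-bond acceptors and net charge stay the same. Within this single pair, 4-methylphenyl gives the stronger inhibition and 4-fluorophenyl the weaker, but no measured property is available to account for that difference.

The two compounds with numbers leave open how a chloro group, a methoxy group or an amine on the same aromatic carbon would read, so one step cannot yet establish a trend at this position. Also open, from the compounds shown here alone, is whether the exchange would give a similar step alongside the side chain of compound 1 and compound 2, for which no result is reported.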